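A Side-Chain Exchange in a Level Series

The compounds below may be only part of what the source reports. "The series", "measured", "known", "first", "only" and "open" are said of these compounds alone.

In a functional assay on HCT-116 cells (Homo sapiens) for cytotoxicity (on this read-out higher numbers stand for weaker inhibition and lower numbers for stronger inhibition), compound 1 `COc1cc(N2CCN(Cc3ccccn3)CC2)ccc1Nc1nc(NC2CCCCC2)c2nc[nH]c2n1` gives 51 nM, compound 2 `COc1cc(N2CCN(CC3CCOC3)CC2)ccc1Nc1nc(NC2CCCCC2)c2nc[nH]c2n1` gives 66 nM, and compound 3 `COc1cc(N2CCC(C(=O)N3CCOCC3)CC2)ccc1Nc1nc(NC2CCCCC2)c2nc[nH]c2n1` gives 50 nM. Compound 3 thus lies within the scatter of both other compounds. Compound 4 `COc1cc(N2CCC(CC(=O)N3CCCC3)CC2)ccc1Nc1nc(NC2CCCCC2)c2nc[nH]c2n1` differs from compound 3 as follows: ((pyrrolidin-1-yl)carbonyl)methyl in place of (morpholin-4-yl)carbonyl on a saturated ring carbon. In short, ((pyrrolidin-1-yl)carbonyl)methyl stands in place of (morpholin-4-yl)carbonyl on a saturated ring carbon. Among the compounds with values here, the only measured step, a 1.3-fold higher number from compound 1 to compound 2 (0.11 log units; within the scatter), concerns another exchange of groups, so it bears on this change only indirectly, and it stays within the scatter. No step beyond the scatter is therefore expected in this assay. The expected size is a 1.1-fold higher number from compound 3 to compound 4 (0.04 log units; within the scatter). Compound 4 is estimated at 55 nM, with an expected range of 25 nM to 120 nM.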

Compound 4, half-maximal inhibitory concentration: 15 nM
Beside the measured number, compound 4's estimate is 3.7-fold (0.56 log units) above it, and the stated range ends above it.
By their numbers in this assay, from the lowest: compound 4; then compounds 3, 1 and 2 (each within the scatter of the next).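

In this assay, within the data shown here, the exchange on the saturated ring carbon gives a 3.3-fold lower number from compound 3 to compound 4 (0.52 log units; beyond the scatter), the first step beyond the scatter, so this position does respond to the group it carries. The number moved although the heavy-atom count of the group stayed the same, while the ring, the chain and the hydrogen-bond acceptor count all changed. Nothing at hand explains the step. As far as these compounds go, the entering group alters the ring and the chain together, so which of them carries the step stays open. A (pyrrolidin-1-yl)carbonyl or a ((morpholin-4-yl)carbonyl)methyl group on that carbon would separate the two.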